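This account rests on a few compounds, and the source may have more. Where it says the series, first, only, none or still open, it means among the compounds named here.

In a physicochemical assay for solubility, read by LC-MS, in phosphate buffer, with a stated time of 24 h, at pH 7.4 (a lower number here means a less soluble compound, a higher number a more soluble compound), compound 3 `COCCC(=O)Nc1cnc(NCc2c(F)ccc3c2CCO3)n2cnnc12` gives 980000 nM, the higher of the two actual numbers in this small set. Compound 1 `C[C@@H]1CC(=O)N(c2cnc(NCc3c(F)ccc4c3CCO4)n3cnnc23)C1` gives 130000 nM. Compound 2 `O=C1CCCN1c1cnc(NCc2c(F)ccc3c2CCO3)c2cn[nH]c(=O)c12` returns only a limit, < 2000 nM. The next structure, compound 4 `O=C(Nc1cnc(NCc2c(F)ccc3c2CCO3)n2cnnc12)c1cccnc1`, keeps the rest of compound 3 and changes the group on the carbonyl: pyridin-3-yl in place of 2-methoxyethyl on a carbonyl carbon. Pyridin-3-yl stands in place of 2-methoxyethyl on a carbonyl carbon, so a chain with no ring gives way to a six-membered aromatic ring. Going by the values given here, one measured step bears on this, a 7.5-fold higher number from compound 1 to compound 3 (0.88 log units; beyond the scatter). It exchanges different groups, so it offers a size rather than a direct precedent. Compound 3 already stands at the top of the numbers, and a step of about that size, downward, is expected in this assay. The estimate is a 6.5-fold lower number from compound 3 to compound 4 (0.82 log units; beyond the scatter). The expected value for compound 4 is 150000 nM, with an estimated range of 30000 nM to 600000 nM.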

Compound 4, solubility: 12000 nM
Beside the measured number, compound 4's estimate is 13-fold (1.10 log units) above it; the measured number lies below the stated range.
By their numbers in this assay, from the lowest: compound 4; then compound 1; then compound 3. At a limit, below all of these: compound 2.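

In this assay, the group on the carbonyl carbon proves to matter greatly: pyridin-3-yl in place of 2-methoxyethyl brings an 82-fold lower number from compound 3 to compound 4 (1.91 log units; beyond the scatter) in a single change. The earlier 7.5-fold higher number from compound 1 to compound 3 (0.88 log units; beyond the scatter) might have suggested that exchanging 4-methyl-2-oxopyrrolidin-1-yl for an amide raises the number, but with (pyridin-3-yl)carbonyl on that nitrogen the result is an 11-fold lower number from compound 1 to compound 4 (1.03 log units; beyond the scatter) instead, so the direction of that exchange depends on the group carried by the carbonyl. Nothing measured here gives a cause for these steps.

The compounds shown leave open whether the lower number goes with the aromatic ring as such or with its ring nitrogen. A phenyl ring, a saturated ring such as tetrahydropyran-4-yl, or a longer ether chain on the same carbonyl would help to separate these readings.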